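A few compounds are considered here, and "the series" means these few. Any claim that something is new, unique, unknown or untested is made for them only; others in the source may bear on it.

Within the data shown here, in a functional assay on HT-29 cells (Homo sapiens) for inhibition, read by luminescence and CellTiter-Glo, with a stated time of 24 h (on this read-out higher numbers stand for an effect only at larger amounts of compound and lower numbers for an effect already at smaller amounts), compound 2 `CN1C(=S)[C@@H](NC(=O)c2nc(Cc3ccccc3)n(C3COC3)n2)COc2ccccc21` holds the lower of the two numbers so far at 916 nM while compound 1 `CN1C(=S)[C@@H](NC(=O)c2nc(Cc3ccccc3)n(C3CCCCC3)n2)COc2ccccc21` gives 4000 nM on the same read-out. Compound 3 `CN1C(=S)[C@@H](NC(=O)c2nc(Cc3ccccc3)n(C3CCOC3)n2)COc2ccccc21` carries oxolan-3-yl in place of oxetan-3-yl on an aromatic nitrogen. Among the measured compounds shown here, the only measured step at this place is modest, a 4.4-fold lower number from compound 1 to compound 2 (0.64 log units; beyond the scatter) with oxetan-3-yl in place of cyclohexyl. Only a small rise in this assay is therefore expected, probably within the scatter. The expected size is a 1.4-fold higher number from compound 2 to compound 3 (0.15 log units; within the scatter) as an estimate. Estimated for compound 3 is 1300 nM with 550 nM to 3000 nM as the expected range.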

Compound 3, half-maximal effective concentration: 1580 nM
Compound 3: middle estimate off by 1.2-fold (0.08 log units), on the low side, within the range that was stated.
By their numbers in this assay, from the lowest: compounds 2 and 3 (each within the scatter of the next); then compound 1.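

In this assay, oxolan-3-yl in place of oxetan-3-yl on the aromatic nitrogen stays within the scatter, with a 1.7-fold higher number from compound 2 to compound 3 (0.24 log units; within the scatter), so the five-membered ring with one oxygen cannot be told apart from the four-membered one. The advantage over cyclohexyl carries over to this second oxygen-bearing ring, with a 2.5-fold lower number from compound 1 to compound 3 (0.40 log units; beyond the scatter). Nothing at hand explains either step. Open, as far as these compounds go, is how a cyclobutyl or cyclopentyl group would read on this nitrogen, which would separate the ring oxygen from ring size. From the compounds shown here alone, an azetidin-3-yl amine at the same place is equally open.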